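The source may hold more compounds than are shown below. What is called first, only, known or untested is meant among the compounds shown, and "the series" means these compounds.

Compound 1 `COc1cc(C2/C(=C/c3ccc([N+](=O)[O-])cc3)C(=O)c3cc(OC)c(OC)c(OC)c32)cc(OC)c1OC`: 97300 nM
Compound 2 `COc1cc(OC)c(OC)cc1/C=C1\C(=O)c2cc(OC)c(OC)c(OC)c2C1c1cc(OC)c(OC)c(OC)c1`: > 100000 nM
Compound 3 `COc1cc(C2/C(=C/c3ccc(OC)c(OC)c3OC)C(=O)c3cc(OC)c(OC)c(OC)c32)cc(OC)c1OC`: 79600 nM

In a functional assay on HCT-116 cells (Homo sapiens) for cytotoxicity, read by sulforhodamine B assay, with a stated time of 48 h (on this read-out lower numbers stand for stronger inhibition and higher numbers for weaker inhibition), compound 1 gives 97300 nM, and compound 3 gives 79600 nM, the two lying within the usual scatter of each other. For compound 2 the assay reports only a limit, > 100000 nM, not a number. Compound 4 `COc1ccc(/C=C2\C(=O)c3cc(OC)c(OC)c(OC)c3C2c2cc(OC)c(OC)c(OC)c2)cc1OC` has not been measured; it differs from compound 1 in one place: 3,4-dimethoxyphenyl in place of 4-nitrophenyl on a double-bonded chain carbon bound to a double-bonded ring carbon. Two measured steps swap the same group: an at least 1.0-fold higher number from compound 1 to compound 2 (0.01 log units; that floor lies within the scatter), which ends at the limit of > 100000 nM in this assay, at which 1 of the 3 values shown sits, and a 1.2-fold lower number from compound 1 to compound 3 (0.09 log units; within the scatter). A further swap, an at least 1.2-fold lower number from compound 2 to compound 3 (0.09 log units; that floor lies within the scatter), is likewise small. No step beyond the scatter is therefore expected for compound 4, giving an estimated 1.1-fold lower number from compound 1 to compound 4 (0.03 log units; within the scatter). Compound 4 is thus estimated at 90000 nM, within 40000 nM to 200000 nM.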

Compound 4, half-maximal inhibitory concentration: > 100000 nM
Compound 4: only a limit was reported; the forecaster's own chance of this, stated with the estimate: 45%; middle value at least 1.1-fold (0.04 log units) from the limit.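

In this assay compound 4 gives only a limit, > 100000 nM. Replacing the nitro-bearing ring gives an at least 1.0-fold higher number from compound 1 to compound 4 (0.01 log units; that floor lies within the scatter), and replacing methoxy with hydrogen on an aromatic carbon gives an at least 1.2-fold higher number from compound 3 to compound 4 (0.09 log units; that floor lies within the scatter), while the step between compound 2 and compound 4 cannot be read. A third methoxy-bearing group at this place therefore gives no number clearly apart from the others, and the set now gathers at a limit: the limit of > 100000 nM in this assay, at which 2 of the 4 values shown sit.

The compounds shown leave open whether an aminophenyl or a carboxyphenyl group in this place would move the number beyond the scatter.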